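Isobutyl Ester Returns on a Longer Chain

The source may report more compounds than this note shows. Statements on the series, on what has been measured and on what is new or still open speak of the compounds shown alone.

Compound 1 `CC(C)COC(=O)c1cc(CN2CCCC2)c(O)c(CN2CCCC2)c1` and compound 2 `CC(C)OC(=O)c1cc(CN2CCCC2)c(O)c(CN2CCCC2)c1` differ only in the ester. In a functional assay for inhibition, with Cavia porcellus as the target (on this read-out lower numbers stand for an effect already at smaller amounts and higher numbers for an effect only at larger amounts of compound), compound 1 gives 2.3 ug/mL, and compound 2 gives 11.4 ug/mL, the highest of the two numbers. Among the measured compounds shown here, the only measured step, a 5.0-fold higher number from compound 1 to compound 2 (0.70 log units; beyond the scatter), shows that isopropyl in place of isobutyl raised the number. Compound 3 `CC(C)COC(=O)CCc1cc(CN2CCCC2)c(O)c(CN2CCCC2)c1` brings (2-(isobutoxycarbonyl)ethyl in place of isopropoxycarbonyl on an aromatic carbon), so the isobutyl ester comes back, now held on a longer chain. For the measured compounds named here, only that single step bears on this change, and no measured compound carries the longer chain. Compound 3 is therefore expected to give a lower number, a 3.3-fold lower number from compound 2 to compound 3 (0.51 log units; beyond the scatter), with an estimate of 3.5 ug/mL in this assay, between 1.2 ug/mL and 10 ug/mL.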

Compound 3, concentration for half-maximal effect: 14 ug/mL
Compound 3: the middle estimate sits 4.0-fold (0.60 log units) below what was measured; measured number above the stated range.
By their numbers in this assay, from the lowest: compound 1; then compounds 2 and 3 (each within the scatter of the next).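

In this assay, the step of a 1.2-fold higher number from compound 2 to compound 3 (0.09 log units; within the scatter) leaves 2-(isobutoxycarbonyl)ethyl and isopropoxycarbonyl indistinguishable on this aromatic carbon, so bringing back the isobutyl ester on the longer chain does not restore the low number of compound 1. With the isobutyl kept, replacing isobutoxycarbonyl with 2-(isobutoxycarbonyl)ethyl gives a 6.1-fold higher number from compound 1 to compound 3 (0.78 log units; beyond the scatter), so at this position the ester's attachment matters as well as its alkyl group. Nothing measured here explains this result. The compounds shown leave open whether the isobutyl ester would fare better on a one-carbon chain. They also leave open how a carboxylic acid or an amide would behave at the end of the longer chain.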